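A few compounds are considered here, and "the series" means these few. Any claim that something is new, unique, unknown or untested is made for them only; others in the source may bear on it.

Of the compounds shown here, three have so far been tested in a functional assay on MCF7 cells (Homo sapiens) for antiproliferative activity, read by MTT assay, with a stated time of 48 h; on this read-out higher numbers stand for weaker inhibition and lower numbers for stronger inhibition. In it, compound 1 `COc1ccc(-c2nc(SCC(=O)c3sc(-c4ccccc4)nc3C)nc(N)c2C#N)cc1` gives 27200 nM, compound 2 `COc1ccc(-c2nc(C)c(C(=O)CSc3nc(N)c(C#N)c(-c4ccccc4)n3)s2)cc1` gives 72100 nM and compound 3 `COc1ccc(-c2nc(C)c(C(=O)CSc3nc(-c4ccc(OC)c(OC)c4)c(C#N)c(=O)[nH]3)s2)cc1` gives 24000 nM. Compound 1 thus lies within the usual scatter of compound 3, while compound 2 carries a higher number, which means weaker inhibition, and its gap to compound 1 lies beyond the scatter.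

The next compound to be measured, compound 4 `Cc1nc(-c2ccccc2)sc1C(=O)CSc1nc(N)c(C#N)c(-c2ccc(Cl)cc2)n1`, differs from compound 1 in one place: chloro in place of methoxy on an aromatic carbon. Compound 4 thus carries 4-chlorophenyl where compound 1 carries 4-methoxyphenyl. Going by the values given here, no two measured compounds differ in just one place, and the data offer no direct guide to this change. In this assay, no step beyond the scatter is expected, and neither direction is favoured. The estimated step runs a 1.1-fold lower number from compound 1 to compound 4 (0.04 log units; within the scatter). The estimate for compound 4 is 25000 nM, with an expected range of 9000 nM to 70000 nM.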

Compound 4, half-maximal inhibitory concentration: 20200 nM
Compound 4: middle estimate off by 1.2-fold (0.09 log units), on the high side; the range from low to high includes it.
By their numbers in this assay, from the lowest: compounds 4, 3 and 1 (each within the scatter of the next); then compound 2.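

In this assay, going by these compounds alone, replacing the 4-methoxyphenyl of compound 1 with 4-chlorophenyl gives a 1.3-fold lower number from compound 1 to compound 4 (0.13 log units; within the scatter), and this is the only step so far between two compounds that differ in one place. It shows that, on this aromatic carbon para to a large group, methoxy can give way to chloro, with one heavy atom and one hydrogen-bond acceptor fewer, without the number moving beyond the usual scatter. No measurement is available that would explain this result.

From the compounds shown here alone, whether an amine, a carboxylic acid or a longer chain at the same carbon would shift the number beyond the scatter remains open. A single step also cannot show whether the same exchange would behave alike on the core of compound 2 or compound 3.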